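This account rests on a few compounds, and the source may have more. Where it says the series, first, only, none or still open, it means among the compounds named here.

The study concerns a small series built on the shared core seen in compound 1 `O=C1NC2(CC2c2ccc3cccc(OCc4ccccc4)c3n2)C(=O)N1c1ccc(C(F)(F)F)cc1` and compound 2 `O=C1NC(=O)C2(CC2c2ccc3cccc(OCc4ccccc4)c3n2)N1`. In a functional assay on the whole organism (strain Kunming) with Mus musculus as the target, in the maximal electroshock model, with a stated time of 0.5 h (on this read-out higher numbers stand for an effect only at larger amounts of compound and lower numbers for an effect already at smaller amounts), compound 1 gives 300 mg/kg, and in this assay compound 2 gives 300 mg/kg. The step of no change at the digits printed from compound 1 to compound 2 (within the scatter) shows that the read-out is unchanged when hydrogen takes the place of 4-(trifluoromethyl)phenyl on an amide-type nitrogen in a ring, so compound 2 stands level with compound 1, its nearest neighbour, on the numbers at hand.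

Compound 3 `O=C1NC2(CC2c2ccc3cccc(OCc4ccccc4)c3n2)C(=O)N1C1CCCCC1` has not yet been measured. It differs from compound 2 as follows: cyclohexyl in place of hydrogen on an amide-type nitrogen in a ring. Among the measured compounds shown here, the only measured step that bears on this change is no change at the digits printed from compound 1 to compound 2 (within the scatter), which altered the same amide-type nitrogen in a ring and stayed within the scatter. On that basis no step beyond the scatter is expected in this assay for compound 3 in either direction, and the estimated step is no change at the digits printed from compound 2 to compound 3 (within the scatter). Compound 3 is therefore expected to give 300 mg/kg in this assay, with a range from 150 mg/kg to 600 mg/kg.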

Compound 3, minimum effective dose: 300 mg/kg
Compound 3: middle estimate and measured number agree at the digits printed; the measured number falls inside the stated range.
By their numbers in this assay, from the lowest: compounds 1, 2 and 3 (each within the scatter of the next).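

In this assay, the earlier step had only compared hydrogen with an aromatic group on this amide-type nitrogen in a ring, whereas cyclohexyl now brings a six-membered non-aromatic ring of carbon only to the same place and gives no change at the digits printed from compound 2 to compound 3 (within the scatter). Set directly against 4-(trifluoromethyl)phenyl, cyclohexyl gives no change at the digits printed from compound 1 to compound 3 (within the scatter), so at this position the read-out does not separate hydrogen, an aromatic ring and a non-aromatic carbon ring among these three compounds. No accompanying data bear on why the read-out stays level across these groups.

Since all three compounds stand level, they do not show whether any group on this nitrogen can shift the read-out at all, or whether the shared core alone sets this level. As far as these compounds go, what a carboxylic acid, an amine or a longer chain at this nitrogen would give remains open.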